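Dicarboxy amides in the series: from compound 3 to compound 4

This account rests on a few compounds, and the source may have more. Where it says the series, first, only, none or still open, it means among the compounds named here.

Measured in a functional assay on PC-3 cells (Homo sapiens) for antiproliferative activity, read by MTT assay, with a stated time of 24 h; on this read-out higher numbers stand for weaker inhibition and lower numbers for stronger inhibition:
- compound 1 `CCn1c(C(=O)NC2(CO)CC2)ccc1C(CC)(CC)c1ccc(OCS(=O)(=O)c2ccccc2)c(C)c1`: 3560 nM
- compound 2 `CCn1c(C(=O)NCCCO)ccc1C(CC)(CC)c1ccc(OCS(=O)(=O)c2ccccc2)c(C)c1`: 11300 nM
- compound 3 `CCn1c(C(=O)N[C@@H](CC(=O)O)C(=O)O)ccc1C(CC)(CC)c1ccc(OCS(=O)(=O)c2ccccc2)c(C)c1`: > 50000 nM (a limit, not a number)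

Compound 3 has no number, only (the limit of > 50000 nM in this assay, at which 1 of the 3 values shown sits).

Compound 4 `CCn1c(C(=O)N[C@@H](CCC(=O)O)C(=O)O)ccc1C(CC)(CC)c1ccc(OCS(=O)(=O)c2ccccc2)c(C)c1` differs from compound 3 in one place: carboxymethyl in place of carboxy on a saturated chain carbon, two bonds along the chain from an amide-type nitrogen and a carbonyl carbon. This is carboxymethyl in place of carboxy on a saturated chain carbon, two bonds along the chain from an amide-type nitrogen and a carbonyl carbon, so 1,2-dicarboxyethyl becomes 1,3-dicarboxypropyl.

Going by the values given here, no measured step covers this change directly. The nearest evidence is the pair of steps into the 1,2-dicarboxyethyl amide: an at least 14-fold higher number from compound 1 to compound 3 (1.14 log units; beyond the scatter), large, and an at least 4.4-fold higher number from compound 2 to compound 3 (0.64 log units; beyond the scatter), at least modest. Among the amides with a number, a 3.2-fold higher number from compound 1 to compound 2 (0.50 log units; beyond the scatter) is modest. Compound 4 stays structurally close to compound 3 and far from the hydroxy-bearing amides, so, given an at least 4.4-fold higher number from compound 2 to compound 3 (0.64 log units; beyond the scatter), no step beyond the scatter is expected in this assay, and a further report at the limit is likely.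

Compound 4 is estimated at 50000 nM, with an expected range from 20000 nM to 80000 nM. The expected change is a number no higher from compound 3 to compound 4 (the limit leaves the size open).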

Compound 4, half-maximal inhibitory concentration: > 50000 nM
Compound 4 ended at the assay's limit; the forecaster's own chance of this, stated with the estimate: 75%; the middle value lies on the limit itself.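

In this assay compound 4 gives > 50000 nM, which is a limit of the assay and not a number. Set against the two hydroxy-bearing amides, the result is an at least 4.4-fold higher number from compound 2 to compound 4 (0.64 log units; beyond the scatter) and an at least 14-fold higher number from compound 1 to compound 4 (1.14 log units; beyond the scatter), so the weaker inhibition seen with the 1,2-dicarboxyethyl amide is not confined to that one chain: 1,3-dicarboxypropyl, with carboxymethyl in place of carboxy on the saturated chain carbon, also gives no measurable number. The step between the two dicarboxy amides cannot be read, and any difference between them in this position stays hidden because both sit at the limit: the limit of > 50000 nM in this assay, at which 2 of the 4 values shown sit.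

The compounds shown leave open whether both acid groups are needed for this loss, since none carries a single carboxylic acid on this chain, a methyl ester in place of either carboxy, or an amine in its place. Also open, on these data alone, is whether a longer chain between the amide nitrogen and the distal carboxylic acid would bring the series back to a readable number in this assay.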